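The source may report more compounds than this note shows. Statements on the series, on what has been measured and on what is new or still open speak of the compounds shown alone.

Two compounds of a shared core carrying a double-bonded ring carbon have been measured in a functional assay on MCF7 cells (Homo sapiens) for cytotoxicity, read by MTT assay, with a stated time of 72 h; on this read-out lower numbers stand for stronger inhibition and higher numbers for weaker inhibition. Compound 1, `COc1cc(C=C2C(=O)N(c3ccc(Cl)cc3)N(c3ccc(Cl)cc3)C2=O)cc(OC)c1OC`, gives 16200 nM. Compound 2, `COc1ccc(C=C2C(=O)N(c3ccc(Cl)cc3)N(c3ccc(Cl)cc3)C2=O)cc1`, reaches only a limit of the assay rather than a number, at > 128000 nM. On the numbers shown, compound 2 therefore stands at the weak end, a point made by the limit of > 128000 nM in this assay, at which 1 of the 2 values shown sits, and the values of compound 1 and compound 2 show the former as the one with a measured number and the latter as the one without.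

Compound 3, `O=C1C(=C/C=C/c2ccccc2)C(=O)N(c2ccc(Cl)cc2)N1c1ccc(Cl)cc1`, has not yet been measured in this assay. It differs from compound 2 in one place: 2-phenylethenyl in place of 4-methoxyphenyl on a double-bonded chain carbon bound to a double-bonded ring carbon. Within the data shown here, no step between measured compounds describes this kind of change, so no measured guide exists for its size. Given that compound 2 sits at the limit of this assay, the step expected from compound 2 to compound 3 is an at least 2.1-fold lower number from compound 2 to compound 3 (0.32 log units; beyond the scatter), a modest move toward stronger inhibition, with a real chance that compound 3 again returns only a limit. Compound 3 is accordingly estimated at 60000 nM, in a range from 15000 nM to 200000 nM.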

Compound 3, half-maximal inhibitory concentration: 9400 nM
For compound 3 the middle estimate is 6.4-fold (0.81 log units) above the measured one, outside the stated range (below it).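

The earlier compounds shown here gave no measured change at this position, and now there is one: in this assay, 2-phenylethenyl in place of 4-methoxyphenyl on a double-bonded chain carbon bound to a double-bonded ring carbon gives an at least 13-fold lower number from compound 2 to compound 3 (1.13 log units; beyond the scatter). The entering group holds no oxygen, yet compound 3 returns a number, 9400 nM, so a methoxy group on the aromatic ring at this place is not required for a measured value. The step can be read only as a bound, and its full size stays unknown because compound 2 has a limit and not a number: the limit of > 128000 nM in this assay, at which 1 of the 3 values shown sits.

The compounds shown leave open whether the gain follows the added double bond of the 2-phenylethenyl group or the loss of the methoxy group, as the change replaces both at once. A plain phenyl group at this place, or a 2-(4-methoxyphenyl)ethenyl group, would separate the two, and a longer chain with a second double bond would show whether the trend extends further.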